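The source may hold more compounds than are shown below. What is called first, only, known or untested is meant among the compounds shown, and "the series" means these compounds.

Measured so far:
Compound 1 `OCC(O)C(O)C(O)COC/C=C/C(F)(F)C(F)(F)C(F)(F)C(F)(F)F`: in a physicochemical assay for solubility (on this read-out higher numbers stand for higher solubility and lower numbers for lower solubility), compound 1 gives only the limit < 5000 ug/mL.
Compound 2 `OCC(O)C(O)C(O)COC/C=C/C(F)(F)C(F)(F)C(F)(F)C(F)(F)C(F)(F)C(F)(F)F`: in this assay compound 2 gives only the limit < 1000 ug/mL.

Within the data shown here, the one measured step, a step that the two limits leave unreadable from compound 1 to compound 2, cannot be sized; its two values are the limits the limit of < 5000 ug/mL in this assay, at which 1 of the 2 values shown sits, and (the limit of < 1000 ug/mL in this assay, at which 1 of the 2 values shown sits). So compound 2 stands at a limit, with no readable number behind it.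

Compound 3 `OCC(O)C(O)C(O)COC/C=C/C(F)(F)C(F)(F)C(F)(F)C(F)(F)C(F)(F)C(F)(F)C(F)(F)C(F)(F)F` differs from compound 2 by 1,1,2,2,2-pentafluoroethyl in place of fluoro on a saturated chain carbon bound to two fluorine atoms and a saturated chain carbon. Among the measured compounds shown here, no measured step gives a size or direction for this change. Compound 3 is expected to give 300 ug/mL, between 30 ug/mL and 1000 ug/mL. This expected step, a step that the limit leaves unreadable from compound 2 to compound 3, is a guess rather than a reading from any measured step.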

Compound 3, solubility: 50 ug/mL
Estimate against measurement, compound 3: 6.0-fold (0.78 log units) above, and the stated range covers the measured number.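

Compound 2 has only a limit in this assay, not a number, so neither its step from compound 1 nor its step to compound 3 can be read. The compounds shown leave open how large each step is, and in which direction it goes.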